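The source may hold more compounds than are shown below. What is called first, only, known or untested is meant among the compounds shown, and "the series" means these compounds.

Measured compounds:
compound 1, `CC(C)OC(=O)N1CCC(Oc2ncnc3c2CCN3c2ccc(S(C)(=O)=O)cc2F)CC1`, 91%
compound 2, `CC(C)COC(=O)N1CCC(Oc2ncnc3c2CCN3c2ccc(S(C)(=O)=O)cc2F)CC1`, 94%
compound 3, `CSC(=O)N1CCC(Oc2ncnc3c2CCN3c2ccc(S(C)(=O)=O)cc2F)CC1`, 135%

In a functional assay on CHO-K1 cells with Glucose-dependent insulinotropic receptor (Homo sapiens) as the target, read by a luciferase reporter, with a stated time of 5 h (a lower number here means a smaller maximal response, a higher number a larger maximal response), compound 3 gives the highest number of the three; its nearest neighbour is compound 2, and the separation between them is a number 41 percentage points higher from compound 2 to compound 3 (beyond the scatter), while the separation from compound 1 is a number 44 percentage points higher from compound 1 to compound 3 (beyond the scatter). Compound 4, `CC(C)SC(=O)N1CCC(Oc2ncnc3c2CCN3c2ccc(S(C)(=O)=O)cc2F)CC1`, differs from compound 3 by isopropyl in place of methyl on a sulfur. Within the data shown here, no measured step alters the group on the sulfur, so the closest guide is the step on the oxygen, a number 3 percentage points higher from compound 1 to compound 2 (within the scatter), where a change of alkyl size left the response unmoved. For compound 4 the step is therefore expected to be small, a number 5 percentage points lower from compound 3 to compound 4 (within the scatter), staying near the level of compound 3. Compound 4 is estimated to give 130%, within a range from 105% to 155%.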

Compound 4, largest response reached (reported as percent of maximum), in percent of the reference or control that the assay uses: 138%
For compound 4 the middle estimate is 8 percentage points below the measured one; the range from low to high includes it.
By their numbers in this assay, from the lowest: compounds 1 and 2 (each within the scatter of the next); then compounds 3 and 4 (each within the scatter of the next).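

In this assay the response stays level when the group on the sulfur grows from methyl to isopropyl, with a number 3 percentage points higher from compound 3 to compound 4 (within the scatter) as the step, so this position accepts the larger alkyl group without losing the high response. The high level therefore does not belong to methylsulfanyl alone: isopropylsulfanyl also stands well clear of both oxygen compounds, with a number 44 percentage points higher from compound 2 to compound 4 (beyond the scatter) and a number 47 percentage points higher from compound 1 to compound 4 (beyond the scatter) as the steps. As far as these compounds go, whether a longer chain on the sulfur or an amine on the carbonyl carbon would hold this level remains open. Nothing here gives a measured reason for the separation between the sulfur and oxygen compounds.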